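A second amino acid ester on compound 2

This account rests on a few compounds, and the source may have more. Where it says the series, first, only, none or still open, it means among the compounds named here.

Compound 1 `N[C@@H](CC(=O)OC[C@H]1O[C@@H](n2cc(F)c(=O)[nH]c2=O)C[C@@H]1O)C(=O)O` gives 3600000 nM
Compound 2 `CC(C)[C@H](N)C(=O)OC[C@H]1O[C@@H](n2cc(F)c(=O)[nH]c2=O)C[C@@H]1O` gives 4200000 nM

In a functional assay on MIA PaCa-2 cells (Homo sapiens) for inhibition, read by MTT assay, with a stated time of 24 h (a higher number here means a weaker inhibitor of growth, a lower number a stronger inhibitor of growth), compound 2 gives 4200000 nM and stands level with compound 1, since the step of a 1.2-fold higher number from compound 1 to compound 2 (0.07 log units; within the scatter) does not separate them. Compound 3 `CC(C)[C@H](N)C(=O)OC[C@H]1O[C@@H](n2cc(F)c(=O)[nH]c2=O)C[C@@H]1OC(=O)[C@@H](N)C(C)C` differs from compound 2 by one change: (1-amino-2-methylpropyl)carbonyl in place of hydrogen on an oxygen on a saturated carbon and this turns a hydroxy into ((1-amino-2-methylpropyl)carbonyl)oxy on an oxygen on a saturated carbon. Going by the values given here, only one measured step exists, and the step of a 1.2-fold higher number from compound 1 to compound 2 (0.07 log units; within the scatter) concerns a group on a carbonyl carbon and not this oxygen. It gives only weak guidance. With nothing measured at this oxygen, no change beyond the scatter is expected in this assay and the range must stay wide. The expected step is a 1.1-fold lower number from compound 2 to compound 3 (0.02 log units; within the scatter) and it remains an estimate. For compound 3 the estimated value is 4000000 nM with an expected range from 1300000 nM to 12000000 nM in this assay.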

Compound 3, concentration for 50% growth inhibition: 2400000 nM
Compound 3: middle estimate off by 1.7-fold (0.22 log units), on the high side, and the stated range covers the measured number.
By their numbers in this assay, from the lowest: compounds 3, 1 and 2 (each within the scatter of the next).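

Going by these compounds alone, this is the first measured change at the oxygen on a saturated carbon whose other neighbour is a saturated ring carbon. In this assay, replacing the hydroxy there with ((1-amino-2-methylpropyl)carbonyl)oxy gives a 1.8-fold lower number from compound 2 to compound 3 (0.24 log units; within the scatter), so a second amino acid ester at this oxygen leaves compound 2 and compound 3 level with each other. Nothing measured here bears on what lies behind this result.

Still open, as far as these compounds go, is whether a small acetyl ester, or an ester carrying a carboxylic acid in place of the 2-methylpropyl side chain, would move the number at this oxygen beyond the scatter. Within the data shown here, it is also open whether a longer alkyl chain on this ester would give a different result from the one seen with compound 3.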